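A Methyl Added to an Aromatic Ring, Twice

A few compounds are considered here, and "the series" means these few. Any claim that something is new, unique, unknown or untested is made for them only; others in the source may bear on it.

Compound 1 `Cn1c(-c2ccc(NC(=O)CSc3nc4ccccc4o3)cc2)nc(-c2ccccc2)c1-c1ccccc1` and compound 2 `Cc1ccc2oc(SCC(=O)Nc3ccc(-c4nc(-c5ccccc5)c(-c5ccccc5)n4C)cc3)nc2c1` share one core and differ by methyl in place of hydrogen on an aromatic carbon. In a functional assay on HT-29 cells (Homo sapiens) for cytotoxicity, read by MTT assay, with a stated time of 24 h, tested at 1.6 ug/mL (on this read-out lower numbers stand for a weaker effect and higher numbers for a stronger effect at the one concentration tested), compound 1 gives 41%, while compound 2 gives 15.5%. That step, a number 25.5 percentage points lower from compound 1 to compound 2 (beyond the scatter), lies beyond the scatter. Compound 3 `Cn1c(-c2ccc(NC(=O)CN3CCN(Cc4ccccc4)CC3)cc2)nc(-c2ccccc2)c1-c1ccccc1` has another core; the difference between the two cores is not broken down here. In this assay compound 3 gives 26%. Compound 4 `Cc1ccc(CN2CCN(CC(=O)Nc3ccc(-c4nc(-c5ccccc5)c(-c5ccccc5)n4C)cc3)CC2)cc1` is still unmeasured and differs from compound 3 by methyl in place of hydrogen on an aromatic carbon. This is the same kind of change, not the same: earlier the new group sat on a ring that is part of a fused or bridged system of two rings, meta to a fused ring and para to a fused ring; here it sits on a six-membered aromatic ring of carbon only, para to a large group. Going by the values given here, because the single earlier example reads a number 25.5 percentage points lower from compound 1 to compound 2 (beyond the scatter), a weaker effect is expected for compound 4, with an estimated step of a number 8 percentage points lower from compound 3 to compound 4 (within the scatter), though one example on a different ring leaves the size uncertain. Compound 4 is expected to give about 18% in this assay, probably between 8% and 32%.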

Compound 4, a percentage reported as activity, at one concentration (the size of the read-out at that concentration, not a potency): 26.4%
Compound 4: the middle estimate sits 8.4 percentage points below what was measured; measured number inside the range.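

In this assay, putting methyl in place of hydrogen on the benzyl group gives a step that stays within the scatter: a number 0.4 percentage points higher from compound 3 to compound 4 (within the scatter). The same change therefore does not carry over in size from one core to the other: the same change on two cores in this assay, a number 25.5 percentage points lower (beyond the scatter) from compound 1 to compound 2 and a number 0.4 percentage points higher (within the scatter) from compound 3 to compound 4, 25.9 percentage points apart, beyond the scatter of two such steps. Going by these compounds alone, with only one pair on each core, this does not show what separates the two steps, as the methyl also sits on a different ring in each pair, and it gives no rule for other cores.

Left open is how a methoxy group or a chlorine atom in place of that methyl would read on either core. Also open, on these data alone, is whether the two steps would look the same at other concentrations.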